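From 3-methylphenyl to 2-isopropylphenyl: working notes

A few compounds are considered here, and "the series" means these few. Any claim that something is new, unique, unknown or untested is made for them only; others in the source may bear on it.

In a functional assay on MCF7 cells (Homo sapiens) for inhibition, read by CCK-8 assay, with a stated time of 48 h (a lower number here means a stronger inhibitor of growth, a higher number a weaker inhibitor of growth), compound 1 `Cc1ccccc1Nc1nc(Nc2ccc(N3CCN(C)CC3)cn2)ncc1Cl` gives 5210 nM and compound 2 `Cc1cccc(Nc2nc(Nc3ccc(N4CCN(C)CC4)cn3)ncc2Cl)c1` gives 7160 nM, two values within the scatter of each other. Compound 3 `CC(C)c1ccccc1Nc1nc(Nc2ccc(N3CCN(C)CC3)cn2)ncc1Cl` is unmeasured and differs from compound 2 thus: 2-isopropylphenyl in place of 3-methylphenyl on a nitrogen on an aromatic ring. Going by the values given here, the only measured step bearing on this, a 1.4-fold higher number from compound 1 to compound 2 (0.14 log units; within the scatter), exchanged 2-methylphenyl for 3-methylphenyl. Among the compounds with values here, no measured step covers a 2-isopropylphenyl group, so the expectation is uncertain. No change beyond the scatter is expected, the estimate being a 1.3-fold lower number from compound 2 to compound 3 (0.11 log units; within the scatter). Compound 3 is estimated at 5500 nM, with an expected range of 2000 nM to 15000 nM.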

Compound 3, concentration for 50% growth inhibition: 4360 nM
Estimate against measurement, compound 3: 1.3-fold (0.10 log units) above; low and high end bracket the measured number.
By their numbers in this assay, from the lowest: compounds 3, 1 and 2 (each within the scatter of the next).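

Isopropyl in place of methyl on an aromatic carbon gives a 1.2-fold lower number from compound 1 to compound 3 (0.08 log units; within the scatter) in this assay, so the larger alkyl group leaves the number unmoved beyond the scatter. The exchange of 3-methylphenyl for 2-isopropylphenyl, a 1.6-fold lower number from compound 2 to compound 3 (0.22 log units; within the scatter), also stays within the scatter, so the three alkyl-substituted phenyl groups on this nitrogen cannot be told apart in this read-out. No evidence on the origin of these numbers is at hand. Open, going by these compounds, is whether any group here moves the number beyond the scatter. A phenyl ring carrying an amine, a carboxylic acid or a tert-butyl group would test this.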